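Chlorobenzyl positional change on a low-inhibition series

The source may report more compounds than this note shows. Statements on the series, on what has been measured and on what is new or still open speak of the compounds shown alone.

Compound 1 `CC1=C(C(=O)Nc2ccc(F)cc2)C(c2ccc([N+](=O)[O-])cc2)N=C(SCc2ccccc2Cl)N1`, compound 2 `CC1=C(C(=O)Nc2ccc(F)cc2)C(c2ccc([N+](=O)[O-])cc2)N=C(SCc2cccc(Cl)c2)N1` and compound 3 `COc1ccc(C2N=C(SCc3ccccc3Cl)NC(C)=C2C(=O)Nc2ccc(Br)cc2)cc1` were measured in a functional assay on the whole organism (artery, strain albino) with Rattus norvegicus as the target, with a stated time of 900 min, at a dose of 10 mg/kg by the oral route; a lower number here means less inhibition, a higher number more inhibition at the dose given (going by the name of the read-out). Compound 1 gives 11.3%, compound 2 gives 10.8% and compound 3 gives 7.2%; all three numbers lie within the scatter of one another. The change 3-chlorophenyl in place of 2-chlorophenyl on a saturated chain carbon bound to a sulfur moved the read-out by a number 0.5 percentage points lower from compound 1 to compound 2 (within the scatter). Compound 4 `COc1ccc(C2N=C(SCc3cccc(Cl)c3)NC(C)=C2C(=O)Nc2ccc(Br)cc2)cc1` has not been measured; it carries the same change on the core of compound 3, namely (3-chlorophenyl in place of 2-chlorophenyl on a saturated chain carbon bound to a sulfur). The difference between the core of compound 1 and the core of compound 3 is not broken down here. For compound 4 the step is expected to resemble that seen in this assay from compound 1 to compound 2, because a number 0.5 percentage points lower from compound 1 to compound 2 (within the scatter) was within the scatter; compound 4 is thus estimated to move by a number 0.2 percentage points lower from compound 3 to compound 4 (within the scatter). Compound 4 is expected to give about 7%, with a range from 0% to 17%.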

Compound 4, a percentage reported as inhibition, in the whole organism at one dose (the size of the read-out at that dose, not a potency): 22.6%
For compound 4 the middle estimate is 15.6 percentage points below the measured one, and the stated range ends below it.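

In this assay, 3-chlorophenyl in place of 2-chlorophenyl on a saturated chain carbon bound to a sulfur gives a number 15.4 percentage points higher from compound 3 to compound 4 (beyond the scatter). The effect of this change therefore depends on the core in this pair of cores: the same change on two cores in this assay, a number 0.5 percentage points lower (within the scatter) from compound 1 to compound 2 and a number 15.4 percentage points higher (beyond the scatter) from compound 3 to compound 4, 15.9 percentage points apart, beyond the scatter of two such steps. This does not show which core difference matters, since the cores differ in more than one place, with nitro and fluoro groups in compound 1 and methoxy and bromo groups in compound 3, and two cores set no general rule for the series.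

The compounds shown leave open which of those groups governs the size of the step. They also leave open how the read-out responds to an amine or a longer chain in place of the chlorobenzyl group.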